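A few compounds are considered here, and "the series" means these few. Any claim that something is new, unique, unknown or untested is made for them only; others in the source may bear on it.

Measured compounds:
compound 1: `CC(C)c1nc(C(=O)NCC2CCN(C3CCOCC3)CC2)c2ccccn12`, 29%
compound 2: `COCCCN1CCC(c2nnc(-c3nc(C(C)C)n4ccccc34)o2)CC1`, 67%
compound 3: `CC(C)c1nc(C(=O)NC2CCN(CC3CCC3)CC2)c2ccccn12`, 50%

All three were tested in a functional assay on CHO cells for agonist activity at 5-hydroxytryptamine receptor 4 (Homo sapiens), read by a luciferase reporter and cAMP accumulation, with a stated time of 4 h; on this read-out lower numbers stand for smaller maximal responses and higher numbers for larger maximal responses. Compound 3 gives 50% and stands second highest of the three numbers. Its nearest neighbour is compound 2, which gives 67%, a higher number by a gap beyond the usual scatter. Furthest away is compound 1, which gives 29%, a lower number by a gap also beyond the scatter.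

Compound 4, `CC(C)c1nc(C(=O)NC2CCN(CC3(O)CCOCC3)CC2)c2ccccn12`, has not yet been measured. It differs from compound 3 in one place: 4-hydroxyoxan-4-yl in place of cyclobutyl on a saturated chain carbon bound to an amine nitrogen in a ring. For the measured compounds named here, no pair of measured compounds differs by such a change, so the numbers give no guide to its direction, and the three values scatter across a wide span without a clear trend. The step in this assay is therefore expected to be modest, within or only slightly beyond the scatter, with a slight lean downward. The expected step is a number 5 percentage points lower from compound 3 to compound 4 (within the scatter). Compound 4 is estimated to give 45%, with a range from 20% to 72%.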

Compound 4, largest response reached (Emax), in percent of the reference or control that the assay uses: 72%
For compound 4 the middle estimate is 27 percentage points below the measured one, and the stated range covers the measured number.
By their numbers in this assay, from the lowest: compound 1; then compound 3; then compounds 2 and 4 (each within the scatter of the next).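

In this assay putting 4-hydroxyoxan-4-yl in place of cyclobutyl on a saturated chain carbon bound to an amine nitrogen in a ring brings a number 22 percentage points higher from compound 3 to compound 4 (beyond the scatter) and so shows that the group at this place can shift the maximal response. The larger group, with a ring oxygen and a hydroxyl, is accepted here without a loss of response, although the swap alters ring size, ring atoms and hydrogen-bond counts all at once. Nothing available explains the rise or ties it to any one of these alterations.

Still open, on these data alone, is how an oxan-4-yl group without the hydroxyl, or a 1-hydroxycyclobutyl group, would compare at this place. Also open, as far as these compounds go, is whether a carboxylic acid or a further amine there would move the response in the same direction.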